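Side-chain change from compound 1 to compound 4

The source may report more compounds than this note shows. Statements on the series, on what has been measured and on what is new or still open speak of the compounds shown alone.

Compound 1 `COc1ccc(S(=O)(=O)N(CC(N)=O)c2ccc(N(CC(N)=O)S(=O)(=O)c3ccc(SCCOCCN=C=S)cc3)c3ccccc23)cc1` gives > 10000 nM in an ADME assay on cells (Peritoneal macrophage, Mus musculus) for cytotoxicity, read by CCK-8 assay, with a stated time of 24 h (a lower number here means that less compound is tolerated, a higher number that more compound is tolerated), as a limit, not a number. Compound 2 `COc1ccc(S(=O)(=O)N(CC(N)=O)c2ccc(N(CC(N)=O)S(=O)(=O)c3ccc(SCCOCCOCCOCCN=C=S)cc3)c3ccccc23)cc1` gives > 10000 nM as a limit too. Compound 3 `COc1ccc(S(=O)(=O)N(CC(N)=O)c2ccc(N(CC(N)=O)S(=O)(=O)c3ccc([S+]([O-])CCOCCOCCOCCN=C=S)cc3)c3ccccc23)cc1` gives > 10000 nM as a limit too. Hence the limit of > 10000 nM in this assay, at which 3 of the 3 values shown sit, is all the series shows so far. The change to compound 4 `COc1ccc(S(=O)(=O)N(CC(N)=O)c2ccc(N(CC(N)=O)S(=O)(=O)c3ccc(S(=O)(=O)CCN=C=S)cc3)c3ccccc23)cc1` is a group of 8 heavy atoms (3 carbon, 1 nitrogen, 2 oxygen, 2 sulfur; no ring) in place of a group of 9 heavy atoms (5 carbon, 1 nitrogen, 1 oxygen, 2 sulfur; no ring), on an aromatic carbon and it sits para to a large group. For the measured compounds named here, the one measured step is a step that the two limits leave unreadable from compound 1 to compound 2 and gives no size to carry over, so no step beyond the scatter is expected in this assay for this change. The expected size is a step that the limit leaves unreadable from compound 1 to compound 4 with no direction expected. Compound 4 is estimated at 15000 nM with an expected range from 6000 nM to 40000 nM and a report as a limit is likely.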

Compound 4, half-maximal cytotoxic concentration: > 10000 nM
Compound 4: no number, only a limit (the forecaster's own chance of this, stated with the estimate: 80%); the middle value lies beyond the limit too.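

For the compounds shown here, compound 1 and compound 4 both stand only as limits in this assay, so no step between them can be read. The compounds shown leave open at what concentration any of these side chains becomes cytotoxic, as all remain at one ceiling: the limit of > 10000 nM in this assay, at which 4 of the 4 values shown sit.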